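The compounds below may be only part of what the source reports. "The series", "measured", "known", "first", "only" and "open" are said of these compounds alone.

Series notes. In an assay on isolated protein for inhibition of Melanocyte-stimulating hormone receptor (Mus musculus) (on this read-out lower numbers stand for stronger inhibition and higher numbers for weaker inhibition), compound 1 (`CS(=O)(=O)N(CC1CC1)c1ccccc1N1CCN(C(=O)[C@H](CC(=O)N2CCNCC2)Cc2ccc(Cl)cc2)CC1`) gives > 8000 nM, which is a limit of the assay and not a number. Compound 2 (`CCN(C(C)=O)C(C)c1ccccc1N1CCN(C(=O)[C@H](CC(=O)N2CCC2)Cc2ccc(Cl)cc2)CC1`) gives > 1400 nM in this assay, again a limit rather than a number. On the numbers shown compound 2 therefore sits at the limit of > 1400 nM in this assay, at which 1 of the 2 values shown sits, and compound 1 at the limit of > 8000 nM in this assay, at which 1 of the 2 values shown sits; with both values being limits, neither compound can be placed relative to the other. Compound 3 (`CCN(C(C)=O)C(C)c1ccccc1N1CCN(C(=O)[C@H](CC(=O)NCc2ccccc2F)Cc2ccc(Cl)cc2)CC1`) has not yet been measured. It differs from compound 2 by (2-fluorobenzyl)amino in place of azetidin-1-yl on a carbonyl carbon whose other neighbour is a saturated chain carbon. Within the data shown here, no step between measured compounds is available to anchor the size of this change in this assay. The step from compound 2 to compound 3 is expected to be modest, a step that the limit leaves unreadable from compound 2 to compound 3, in the direction of somewhat stronger inhibition, and may well stay within the scatter. Compound 3 is accordingly expected to give 3000 nM in this assay, within 500 nM to 20000 nM, with a fair chance that only a limit is reported.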

Compound 3, half-maximal inhibitory concentration: > 1600 nM
Compound 3: no number, only a limit (the forecaster's own chance of this, stated with the estimate: 55%); the middle value lies beyond the limit too.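

In this assay compound 3 gives > 1600 nM, which is a limit and not a number. Among these compounds, compound 2 also stands only at a limit, so no step from compound 2 to compound 3 can be read. The compounds shown leave open whether (2-fluorobenzyl)amino in place of azetidin-1-yl on a carbonyl carbon changes inhibition at all.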